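Meta Fluoro for Chloro on a Thioxothiazolidinone Benzylidene

This account rests on a few compounds, and the source may have more. Where it says the series, first, only, none or still open, it means among the compounds named here.

Measured compounds:
compound 1, `O=C1NC(=S)/C(=C/c2cc(Cl)cc(Cl)c2Cl)S1` — 12.6%
compound 2, `O=C1NC(=S)/C(=C/c2cccc(Cl)c2)S1` — -0.36%
compound 3, `O=C1NC(=S)/C(=C/c2ccccc2Cl)S1` — -11.3%

Three compounds share the core shown beside compound 1 and differ only in the chlorine pattern on the aromatic ring. In a functional assay on HEp-2 cells (Homo sapiens) for cytotoxicity, read by MTT assay, with a stated time of 72 h, tested at 1.25 ug/mL (on this read-out lower numbers stand for less inhibition of growth and higher numbers for more inhibition of growth at the one concentration tested), compound 1 gives 12.6%, compound 2 gives -0.36% and compound 3 gives -11.3%. Compound 2 stands second highest of the three numbers: compound 3 lies below it by a gap beyond the scatter, and compound 1 lies above it by a gap also beyond the scatter. All three numbers, however, are small, and none points to strong inhibition of growth at the single concentration used.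

Compound 4, `O=C1NC(=S)/C(=C/c2cccc(F)c2)S1`, has not yet been measured in this assay. It differs from compound 2 by one change: fluoro in place of chloro on an aromatic carbon. Among the compounds with values here, no step of this kind among measured compounds is available, and the single chloro compounds here give numbers close to zero, so a step of no size beyond the scatter is expected in this assay, in no firm direction. The estimated step from compound 2 to compound 4 is therefore a number 1.6 percentage points lower from compound 2 to compound 4 (within the scatter). For compound 4 the expected value in this assay is -2%, with a range from -14% to 10%.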

Compound 4, percent growth inhibition at one concentration: 0.84%
Compound 4: middle estimate off by 2.8 percentage points, on the low side; measured number inside the range.
By their numbers in this assay, from the lowest: compound 3; then compounds 2 and 4 (each within the scatter of the next); then compound 1.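

In this assay, fluoro in place of chloro on an aromatic carbon, at the place meta to a group of 8 heavy atoms, gives a number 1.2 percentage points higher from compound 2 to compound 4 (within the scatter). Within the data shown here, compounds 2 and 4 form the first pair here that differs in one place, and the two cannot be told apart on this read-out, so at this position the one halogen reads the same as the other at the single concentration tested. Nothing available here bears on why this is so.

Going by these compounds, what an amine, a carboxylic acid or a longer chain would give at this place remains open. So does whether the same exchange of chloro for fluoro would stay within the scatter at another place on the ring, or at other concentrations.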